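A few compounds are considered here, and "the series" means these few. Any claim that something is new, unique, unknown or untested is made for them only; others in the source may bear on it.

Measured compounds:

Compound 1, `Cc1nnc(SCc2ccccc2)n1N1C(=O)c2ccccc2C1=O`, gives > 200000 nM in a functional assay on MKN-45 cells (Homo sapiens) for cytotoxicity, read by MTT assay, with a stated time of 48 h; on this read-out higher numbers stand for weaker inhibition and lower numbers for stronger inhibition; this value is a limit of the assay, not a number.
Compound 2, `C#CCSc1nnc(C)n1N1C(=O)c2ccccc2C1=O`, gives > 200000 nM in this assay; this too is a limit of the assay.
Compound 3, `CSc1nnc(C)n1N1C(=O)c2ccccc2C1=O`, gives > 200000 nM in this assay; again a limit, not a number.

Compound 1 therefore stands at the limit of the assay, the same place where every measured value sits (the limit of > 200000 nM in this assay, at which 3 of the 3 values shown sit). The three compounds differ only in the group carried on the saturated carbon bound to the sulfur, and all three steps between them, a step that the two limits leave unreadable from compound 1 to compound 2, a step that the two limits leave unreadable from compound 1 to compound 3 and a step that the two limits leave unreadable from compound 2 to compound 3, cannot be read in size, since both ends of each step are limits.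

Compound 4, `Cc1nnc(SCc2ccccc2Cl)n1N1C(=O)c2ccccc2C1=O`, keeps the benzyl group of compound 1 and differs from it by chloro in place of hydrogen on an aromatic carbon. Among the compounds with values here, none of the measured steps touches a ring carbon of the benzyl group, so no measured step bears directly on this change, and none of them gives a readable size in any case. There is thus no ground to expect a step in either direction beyond the scatter; the most likely outcome is that compound 4 also returns only a limit. The step that the limit leaves unreadable from compound 1 to compound 4 is expected to be essentially none. Compound 4 is therefore estimated at 300000 nM, in the range 100000 nM to 1000000 nM.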

Compound 4, half-maximal inhibitory concentration: > 200000 nM
Compound 4 gave a limit, no number; the forecaster's own chance of this, stated with the estimate: 85%; the middle value does not contradict the limit.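

Compound 4 also gives only a limit, so the steps joining it to compound 1, compound 2 and compound 3 cannot be read in size, since both ends of each are limits: the limit of > 200000 nM in this assay, at which 4 of the 4 values shown sit.

The compounds shown leave open whether any group on the sulfur can give a real number in this assay, and how large such a step would be.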